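The source may report more compounds than this note shows. Statements on the series, on what has been measured and on what is new or still open speak of the compounds shown alone.

Of the compounds shown here, three sharing a furan-3-yl group have been measured in a functional assay on HeLa cells (Homo sapiens) for antiproliferative activity, read by XTT assay, with a stated time of 72 h; on this read-out lower numbers stand for stronger inhibition and higher numbers for weaker inhibition. There, compound 1 `C=C(C)CC[C@]1(C)C2=CCC[C@](C)(C[C@H](O)c3ccoc3)[C@H]2CC[C@H]1C` gives 30200 nM, compound 2 `CC(C)=CCC[C@]1(C)C2=CCC[C@](C)(CC(=O)c3ccoc3)[C@H]2CC[C@H]1C` gives 54500 nM and compound 3 `C=C(C)CCC[C@]1(C)C2=CCC[C@](C)(C[C@@H](O)c3ccoc3)[C@H]2CC[C@H]1C` gives 59400 nM. Compound 1 therefore stands within the usual scatter of both other compounds. Compound 4 `C=C(C)CC[C@]1(C)C2=CCC[C@](C)(C[C@H](O)C3=CC(=O)OC3O)[C@H]2CC[C@H]1C` keeps the core of compound 1 but changes one group, on a saturated chain carbon bound to an oxygen on a saturated carbon and a saturated chain carbon: a group of 7 heavy atoms (4 carbon, 3 oxygen; one five-membered non-aromatic ring with 1 hetero atom) in place of a group of 5 heavy atoms (4 carbon, 1 oxygen; one five-membered aromatic ring with 1 hetero atom), on a saturated chain carbon bound to an oxygen on a saturated carbon and a saturated chain carbon. Going by the values given here, no pair of measured compounds differs in one place, and none lacks the furan-3-yl group, so the data give no direct measure of this replacement. The expectation in this assay is therefore tentative: a moderate step towards a lower number, with a wide margin that includes no change at all. The estimated change is a 2.5-fold lower number from compound 1 to compound 4 (0.40 log units; beyond the scatter). For compound 4 the expected value is 12000 nM, within an estimated range of 3000 nM to 40000 nM.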

Compound 4, half-maximal inhibitory concentration: 4800 nM
Compound 4: middle estimate off by 2.5-fold (0.40 log units), on the high side, within the range that was stated.
By their numbers in this assay, from the lowest: compound 4; then compounds 1, 2 and 3 (each within the scatter of the next).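

In this assay, putting the group of 7 heavy atoms with its five-membered non-aromatic ring in place of furan-3-yl, on a saturated chain carbon bound to an oxygen on a saturated carbon and a saturated chain carbon, gives a 6.3-fold lower number from compound 1 to compound 4 (0.80 log units; beyond the scatter). Going by these compounds alone, the earlier compounds all carried furan-3-yl, so this is the first sign that the number responds to a change of this group, and the step lies beyond the scatter. Nothing measured here accounts for the step.

This single pair cannot separate the contributions of the non-aromatic ring, its carbonyl and its hydroxyl, since all of them enter together. The compounds shown also leave open how an amine or a carboxylic acid would read at this place, and whether the step would recur on the side chains of compound 2 or compound 3.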